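A few compounds are considered here, and "the series" means these few. Any claim that something is new, unique, unknown or untested is made for them only; others in the source may bear on it.

Working notes on the series, in a functional assay on K562 cells (Homo sapiens), read by MTT assay, with a stated time of 72 h; a lower number here means a stronger inhibitor, a higher number a weaker inhibitor. Among the measured compounds shown here, compound 3 (`CNc1ncnc2c1c(-c1ccco1)cn2[C@@H]1O[C@H](CO)[C@@H](O)[C@H]1O`) gives 220 nM, the middle of the three values so far: compound 2 (`C#Cc1cn([C@@H]2O[C@H](CO)[C@@H](O)[C@H]2O)c2ncnc(SC)c12`) lies lower at 30 nM, and compound 1 (`CSc1ncnc2c1c(-c1cccs1)cn2[C@@H]1O[C@H](CO)[C@@H](O)[C@H]1O`) lies higher at 11600 nM. For the measured compounds named here, compound 4 (`CNc1ncnc2c1c(-c1ccsc1)cn2[C@@H]1O[C@H](CO)[C@@H](O)[C@H]1O`) has no measurement yet. It differs from compound 3 by thiophen-3-yl in place of furan-2-yl on an aromatic carbon.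

Going by the values given here, only one measured step touches this position, a 390-fold lower number from compound 1 to compound 2 (2.59 log units; beyond the scatter). That step is large, but it exchanges thiophen-2-yl for ethynyl, so it bears only loosely on an exchange between two five-membered aromatic rings. Among the compounds with values here, compound 1 also differs from compound 3 in more than one place, and no measured pair isolates furan-2-yl against a thiophene ring on the same background. Even so, the only measured compound with a thiophene ring, compound 1 at 11600 nM, has the highest number. A moderate move toward a higher number in this assay is therefore expected, far smaller than the measured step.

The expected step is a 2.7-fold higher number from compound 3 to compound 4 (0.44 log units; beyond the scatter).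

For compound 4 the estimated value is 600 nM, with an expected range from 120 nM to 3000 nM.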

Compound 4, half-maximal inhibitory concentration: > 20000 nM
Compound 4: no number, only a limit (the forecaster's own chance of this, stated with the estimate: 3%); middle value at least 33-fold (1.52 log units) away from the limit.
By their numbers in this assay, from the lowest: compound 2; then compound 3; then compound 1. At a limit, above all of these: compound 4.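

In this assay, exchanging furan-2-yl for thiophen-3-yl on an aromatic carbon gives an at least 90-fold higher number from compound 3 to compound 4 (1.95 log units; beyond the scatter). Among the compounds shown here, this is the first measured pair in which only the five-membered aromatic ring changes on one background, and it shows that two rings of equal heavy-atom count, each with 1 hetero atom, are not interchangeable at this position in this assay. For compound 4 the result is a limit and not a number, so the step has a lower bound only: the limit of > 20000 nM in this assay, at which 1 of the 4 values shown sits.

The exchange alters the hetero atom, oxygen to sulfur, and the point of attachment of the ring together, so the compounds shown leave open which of the two carries the loss, a question that furan-3-yl or thiophen-2-yl on the background of compound 3 would separate. Also open, from the compounds shown here alone, is how this position responds to groups other than these rings and ethynyl on that background, such as a phenyl ring, an amine or a short alkyl chain.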